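A few compounds are considered here, and "the series" means these few. Any claim that something is new, unique, unknown or untested is made for them only; others in the source may bear on it.

Four compounds share one scaffold and differ at two places: the aromatic group on a ring nitrogen and the saturated ring at the end of a chain. Compound 1 `COc1cc2c(Oc3ccc(NC(=O)c4nn(-c5ccccc5OC(F)(F)F)c(=O)cc4C)cc3F)ccnc2cc1OCCCN1CCC(C)CC1` is the reference. In a functional assay on A549 cells (Homo sapiens) for inhibition, read by MTT assay, with a stated time of 72 h (on this read-out higher numbers stand for weaker inhibition and lower numbers for stronger inhibition), compound 1 gives 90 nM. Compound 2 `COc1cc2c(Oc3ccc(NC(=O)c4nn(-c5ccccc5OC(F)(F)F)c(=O)cc4C)cc3F)ccnc2cc1OCCCN1CCN(C)CC1` differs from compound 1 by one change, (4-methylpiperazin-1-yl in place of 4-methylpiperidin-1-yl on a saturated chain carbon, three bonds along the chain from an oxygen on an aromatic ring). In this assay compound 2 gives 130 nM, and the step is a 1.4-fold higher number from compound 1 to compound 2 (0.16 log units; within the scatter). Compound 3 `COc1cc2c(Oc3ccc(NC(=O)c4nn(-c5cccc(F)c5)c(=O)cc4C)cc3F)ccnc2cc1OCCCN1CCC(C)CC1` carries a different core, set apart from compound 1 by 3-fluorophenyl in place of 2-(trifluoromethoxy)phenyl on an aromatic nitrogen. In this assay compound 3 gives 250 nM, a step of a 2.8-fold higher number from compound 1 to compound 3 (0.44 log units; beyond the scatter). Compound 4 `COc1cc2c(Oc3ccc(NC(=O)c4nn(-c5cccc(F)c5)c(=O)cc4C)cc3F)ccnc2cc1OCCCN1CCN(C)CC1` has not been measured. It differs from compound 3 by 4-methylpiperazin-1-yl in place of 4-methylpiperidin-1-yl on a saturated chain carbon, three bonds along the chain from an oxygen on an aromatic ring, the same change at the same place that separates compound 2 from compound 1. For the measured compounds named here, the one measured instance is the only guide: on the core of compound 1 the swap of saturated rings left the number almost where it was, because a 1.4-fold higher number from compound 1 to compound 2 (0.16 log units; within the scatter) sits within the usual scatter. The same small shift is expected on the core of compound 3, so the step is estimated as a 1.4-fold higher number from compound 3 to compound 4 (0.15 log units; within the scatter). On that basis compound 4 is expected to give about 350 nM in this assay. For compound 4 the expected range runs from 160 nM to 800 nM. Whether the change behaves alike on both cores remains to be seen.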

Compound 4, half-maximal inhibitory concentration: 150 nM
Estimate against measurement, compound 4: 2.3-fold (0.37 log units) above; the whole stated range lies above it.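

In this assay, putting 4-methylpiperazin-1-yl in place of 4-methylpiperidin-1-yl on the core with the 3-fluorophenyl group gives a 1.7-fold lower number from compound 3 to compound 4 (0.22 log units; within the scatter), and this step cannot be told apart from the same swap on the core with the 2-(trifluoromethoxy)phenyl group: the same change on two cores in this assay, a 1.4-fold higher number (0.16 log units; within the scatter) from compound 1 to compound 2 and a 1.7-fold lower number (0.22 log units; within the scatter) from compound 3 to compound 4, 2.4-fold (0.38 log units) apart, within the scatter of two such steps. The change of aromatic group, read with 4-methylpiperazin-1-yl at the end of the chain, gives a 1.2-fold higher number from compound 2 to compound 4 (0.06 log units; within the scatter), and although the step with 4-methylpiperidin-1-yl reads a 2.8-fold higher number from compound 1 to compound 3 (0.44 log units; beyond the scatter), the two steps also cannot be told apart: the same change on two cores in this assay, a 2.8-fold higher number (0.44 log units; beyond the scatter) from compound 1 to compound 3 and a 1.2-fold higher number (0.06 log units; within the scatter) from compound 2 to compound 4, 2.4-fold (0.38 log units) apart, within the scatter of two such steps. So the ring swap shows no measurable dependence on the core here, but this rests on just two pairs of steps in one assay, all of them small, so it does not prove that the change carries over reliably, and a modest real difference could still be hidden in the scatter.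

Still open, as far as these compounds go, is whether this holds for other groups at the end of the 3-carbon chain, such as a morpholine ring or a dimethylamine, or for a longer chain. From the compounds shown here alone, it is equally open whether other groups on the aromatic nitrogen, such as an unsubstituted phenyl or a 4-fluorophenyl, would behave the same way.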